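Adding a Methoxy Group to Compound 1

The source may report more compounds than this note shows. Statements on the series, on what has been measured and on what is new or still open speak of the compounds shown alone.

Compound 1 `COc1ccc(C(=O)/C=C/c2cc(-c3cc(OC)c(OC)c(OC)c3)n[nH]2)cc1OC` was tested in a functional assay on UACC-62 cells (Homo sapiens) for inhibition, read by sulforhodamine B assay, with a stated time of 48 h (on this read-out higher numbers stand for weaker inhibition of growth and lower numbers for stronger inhibition of growth), where compound 1 gives 3220 nM. Its close relative compound 2 `COc1ccc(C(=O)/C=C/c2cc(-c3cc(OC)c(OC)c(OC)c3)n[nH]2)cc1` gives 3650 nM in this assay. Among the compounds with values here, of the two numbers known, compound 1 stands at the lower one, but the single measured step between them, a 1.1-fold higher number from compound 1 to compound 2 (0.05 log units; within the scatter), shows that the two compounds cannot be told apart on this read-out.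

Compound 3 `COc1cc(C(=O)/C=C/c2cc(-c3cc(OC)c(OC)c(OC)c3)n[nH]2)cc(OC)c1OC` has not yet been measured in this assay. It differs from compound 1 by methoxy in place of hydrogen on an aromatic carbon. Within the data shown here, the only measured step that bears on such a change is a 1.1-fold higher number from compound 1 to compound 2 (0.05 log units; within the scatter), in which a methoxy group was removed and the number moved by an amount within the scatter. Because a 1.1-fold higher number from compound 1 to compound 2 (0.05 log units; within the scatter) was so small, the addition of a methoxy group is expected to shift this assay for compound 3 by little, with no direction favoured beyond the scatter. Compound 3 is therefore estimated at 3200 nM, with a range from 1100 nM to 9500 nM. The step that this estimate means is a 1.0-fold lower number from compound 1 to compound 3 (0.00 log units; within the scatter), an expected change of no real size.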

Compound 3, concentration for total growth inhibition: 3680 nM
Beside the measured number, compound 3's estimate is 1.2-fold (0.06 log units) below it; the measured number falls inside the stated range.
By their numbers in this assay, from the lowest: compounds 1, 2 and 3 (each within the scatter of the next).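

With a 1.1-fold higher number from compound 1 to compound 3 (0.06 log units; within the scatter), a methoxy group in place of hydrogen, ortho to a methoxy group and meta to a large group, leaves the number in this assay within the scatter of the number for the parent. Read together with a 1.1-fold higher number from compound 1 to compound 2 (0.05 log units; within the scatter), where a methoxy group leaves the same ring, this means that the read-out does not respond to a methoxy group either entering or leaving in these two single changes, so that the methoxy groups on this ring are, in this small set, not seen to matter in either direction. Nothing available explains this flat result, and no measurement beyond the growth numbers themselves bears on it.

As far as these compounds go, what stays open is whether this place tolerates only methoxy or any group, since a primary amine, a carboxylic acid or a longer chain such as butoxy could behave quite differently there. From the compounds shown here alone, it also stays open whether a change elsewhere in the shared core, away from this ring, would move the number beyond the scatter.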